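This account rests on a few compounds, and the source may have more. Where it says the series, first, only, none or still open, it means among the compounds named here.

Measured compounds in a functional assay on CHO cells for positive allosteric modulation of muscarinic acetylcholine receptor M5 (Homo sapiens), read by FLIPR and calcium flux, with a stated time of 1 h; on this read-out lower numbers stand for an effect already at smaller amounts and higher numbers for an effect only at larger amounts of compound:
compound 1 `O=C1C(=O)N(Cc2ccc(-c3cccnc3)cc2)c2ccc(OC(F)(F)F)cc21` gives 1600 nM
compound 2 `O=C1C(=O)N(Cc2ccc(-c3ccccc3)nc2)c2ccc(OC(F)(F)F)cc21` gives 3800 nM
compound 3 `O=C1C(=O)N(Cc2ccc(-c3ccccc3)cc2F)c2ccc(OC(F)(F)F)cc21` gives 5900 nM

Compound 1 stands lowest of the three numbers in this assay. The nearest value is that of compound 2, which lies beyond the usual scatter above compound 1, and the furthest is that of compound 3, which lies further beyond the scatter above compound 1. Going by the values given here, no single-point step between two measured compounds can be drawn from these three, since each pair differs in more than one place; the three numbers only show that the shared core tolerates several aryl-containing substituents on the benzylic ring with values spread across a modest window.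

Compound 4 `O=C1C(=O)N(Cc2ccc(Oc3ccccn3)cc2)c2ccc(OC(F)(F)F)cc21` is the next candidate for this assay. It differs from compound 1 by (pyridin-2-yl)oxy in place of pyridin-3-yl on an aromatic carbon; the new group sits on an aromatic carbon of a six-membered aromatic ring of carbon only, para to a large group. Among the compounds with values here, no measured pair isolates this kind of change, so the size of the step cannot be read from the data; a step in either direction would not be surprising, and a loss is expected slightly more than a gain. The step from compound 1 to compound 4 is estimated at a 1.9-fold higher number from compound 1 to compound 4 (0.27 log units; within the scatter). For compound 4 in this assay the estimate is 3000 nM, with a range from 1000 nM to 10000 nM.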

Compound 4, half-maximal effective concentration: 3200 nM
Estimate against measurement, compound 4: 1.1-fold (0.03 log units) below; low and high end bracket the measured number.
By their numbers in this assay, from the lowest: compounds 1, 4, 2 and 3 (each within the scatter of the next, the first and the last beyond it).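

In this assay, going by these compounds alone, the exchange of pyridin-3-yl for (pyridin-2-yl)oxy on an aromatic carbon, para to a large group, is the only step so far between two compounds that differ in one place, and it comes to a 2.0-fold higher number from compound 1 to compound 4 (0.30 log units; within the scatter). This place therefore accepts a pyridine ring joined through oxygen as well as one joined directly, with no difference beyond the usual scatter in this single comparison. No measurement explains this outcome, and nothing shown bears on its cause.

The step combines two changes, the oxygen link and the ring attachment through pyridin-2-yl rather than pyridin-3-yl, so the compounds shown cannot assign any part of it to either change. Also open, on these data alone, is how this aromatic carbon would respond to a different kind of substituent, such as a morpholine, a carboxylic acid or a pyridine ring joined through a methylene link, since one step within the scatter says little about the wider range of groups possible here.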